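A few compounds are considered here, and "the series" means these few. Any claim that something is new, unique, unknown or untested is made for them only; others in the source may bear on it.

Measured compounds:
- compound 1 `C=CCc1cc(C(C)=O)c(O)cc1OCCCC#N`: 47%
- compound 2 `C=CCc1cc(C(C)=O)c(O)cc1OCCCCC#N`: 92%
- compound 3 `C=CCc1cc(C(C)=O)c(O)cc1OCCCCCCCC#N`: 88%

In an assay on isolated protein for inhibition of leukotriene B4 receptor 1 (Homo sapiens), tested at 10 uM (on this read-out lower numbers stand for less inhibition and higher numbers for more inhibition at the one concentration tested (going by the name of the read-out)), compound 3 stands second highest of the three numbers. Its nearest neighbour is compound 2, whose value lies within the scatter of it (a number 4 percentage points lower from compound 2 to compound 3 (within the scatter)); the furthest is compound 1, far below it (a number 41 percentage points higher from compound 1 to compound 3 (beyond the scatter)).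

The next compound, compound 4 `C=CCc1cc(C(C)=O)c(O)cc1OCCCCCCCCC#N`, is not yet measured. It differs from compound 3 by the following change: cyanomethyl in place of cyano on a saturated chain carbon, seven bonds along the chain from an oxygen on an aromatic ring.

Within the data shown here, two measured steps bear on it. The lengthening of the chain from compound 1 gave large increases (a number 45 percentage points higher from compound 1 to compound 2 (beyond the scatter) and a number 41 percentage points higher from compound 1 to compound 3 (beyond the scatter)), but both start from the short chain of compound 1. Among the measured compounds shown here, the step that resembles the present one most closely, a further lengthening of an already long chain, is the one between compound 2 and compound 3, which lay within the scatter (a number 4 percentage points lower from compound 2 to compound 3 (within the scatter)). On this basis no step beyond the scatter is expected in this assay for compound 4; the estimated change is a number 3 percentage points lower from compound 3 to compound 4 (within the scatter). Compound 4 is therefore expected to give about 85% in this assay, with a range from 68% to 96%.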

Compound 4, a percentage reported as inhibition, at one concentration (the size of the read-out at that concentration, not a potency): 86%
Compound 4: the middle estimate sits 1 percentage points below what was measured, within the range that was stated.
By their numbers in this assay, from the lowest: compound 1; then compounds 4, 3 and 2 (each within the scatter of the next).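

In this assay, lengthening the chain at seven bonds along the chain from the oxygen on the aromatic ring brings no change beyond the scatter, with a number 2 percentage points lower from compound 3 to compound 4 (within the scatter) and a number 6 percentage points lower from compound 2 to compound 4 (within the scatter), while the shortest chain stays well apart, with a number 39 percentage points higher from compound 1 to compound 4 (beyond the scatter). Cyanomethyl in place of cyano is therefore no fixed increment, since the size of the step depends on the chain that carries it: the same change on two cores in this assay, a number 45 percentage points higher (beyond the scatter) from compound 1 to compound 2 and a number 2 percentage points lower (within the scatter) from compound 3 to compound 4, 47 percentage points apart, beyond the scatter of two such steps
The same holds for 4-cyanobutyl in place of cyano, read at three bonds and at four bonds along the chain from the oxygen: the same change on two cores in this assay, a number 41 percentage points higher (beyond the scatter) from compound 1 to compound 3 and a number 6 percentage points lower (within the scatter) from compound 2 to compound 4, 47 percentage points apart, beyond the scatter of two such steps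

The compounds shown leave open whether a longer chain than that of compound 4 would stay within the scatter of it, and whether a carboxylic acid or an amine at the chain end in place of the nitrile would give a similar number. On these data alone, with one concentration as the only read-out, the effects of compound 2, compound 3 and compound 4 at any other concentration also remain open, and at the concentration tested these compounds cannot be ranked against one another here.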